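Methoxy added next to a thione-bearing core

A few compounds are considered here, and "the series" means these few. Any claim that something is new, unique, unknown or untested is made for them only; others in the source may bear on it.

Compounds measured so far:
- compound 1 `CN1C(=O)N(C)C2C1NC(=S)N2/N=C/C=C/c1ccccc1`: 46000 nM
- compound 2 `COc1ccc(/C=C/C=N/N2C(=S)NC3C2N(C)C(=O)N3C)cc1`: > 100000 nM
- compound 3 `CCN1C(=O)N(CC)C2C1N=C(SC)N2/N=C/C=C/c1ccccc1`: 24000 nM

In a functional assay on RD cells (Homo sapiens) for inhibition, read by MTT assay, with a stated time of 72 h (on this read-out higher numbers stand for weaker inhibition and lower numbers for stronger inhibition), compound 1 gives 46000 nM. Compound 2 reaches only the limit of this assay, > 100000 nM, so no number is known for it. Compound 3 gives 24000 nM, which lies within the scatter of the value of compound 1, so the two cannot be ranked against each other.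

Compound 4 `CCN1C(=O)N(CC)C2C1N=C(SC)N2/N=C/C=C/c1ccccc1OC` is not yet measured. It differs from compound 3 in one place: methoxy in place of hydrogen on an aromatic carbon. Among the measured compounds shown here, one measured step bears on this change, the same replacement of hydrogen by methoxy on an aromatic carbon: an at least 2.1-fold higher number from compound 1 to compound 2 (0.33 log units; beyond the scatter), which moved compound 2 onto the limit (the limit of > 100000 nM in this assay, at which 1 of the 3 values shown sits). For compound 4 a similar, modest rise in the number is therefore expected, that is, weaker inhibition, as a 2.0-fold higher number from compound 3 to compound 4 (0.30 log units; within the scatter). Compound 4 is thus estimated at 48000 nM, with a range from 18000 nM to 100000 nM.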

Compound 4, half-maximal inhibitory concentration: 7970 nM
Beside the measured number, compound 4's estimate is 6.0-fold (0.78 log units) above it, outside the stated range (below it).
By their numbers in this assay, from the lowest: compound 4; then compounds 3 and 1 (each within the scatter of the next). At a limit, above all of these: compound 2.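

In this assay, methoxy in place of hydrogen, here ortho to a large group, gives a 3.0-fold lower number from compound 3 to compound 4 (0.48 log units; beyond the scatter), which shows that this change can also go with stronger inhibition. The direction of the step therefore does not carry over from one core to the other: the same change on two cores in this assay, an at least 2.1-fold higher number (0.33 log units; beyond the scatter) from compound 1 to compound 2 and a 3.0-fold lower number (0.48 log units; beyond the scatter) from compound 3 to compound 4, at least 6.5-fold (0.81 log units) apart, beyond the scatter of two such steps. The value of compound 2, > 100000 nM, is a limit of the assay and not a number.

Whether compound 4 owes its lower number to methoxy in particular stays open, as no other group, such as hydroxyl, an amine or ethoxy, is shown at this place. On these data alone, compound 1 and compound 3 differ in more than one place, and which of those differences turns the direction of the step also stays open.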